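Swapping the indazole nitrogen substituent in a platelet inhibition series

The source may hold more compounds than are shown below. What is called first, only, known or untested is meant among the compounds shown, and "the series" means these compounds.

Compound 1: `CCOC(=O)c1ccc(-c2nn(Cc3ccc(OC)cc3)c3ccccc23)cc1`, 620 nM
Compound 2: `COC(=O)c1ccc(-c2nn(Cc3ccccc3)c3ccccc23)cc1`, 560 nM
Compound 3: `CC(C)OC(=O)c1ccc(-c2nn(Cc3ccccc3)c3ccccc23)cc1`, > 10000 nM

In a functional assay on cells (Platelet, Homo sapiens) for inhibition (on this read-out lower numbers stand for stronger inhibition and higher numbers for weaker inhibition), compound 1 gives 620 nM, and compound 2 gives 560 nM, the two sitting within the scatter of one another. Compound 3 reaches only a limit, (the limit of > 10000 nM in this assay, at which 1 of the 3 values shown sits). Within the data shown here, the one measured step, an at least 17-fold higher number from compound 2 to compound 3 (1.25 log units; beyond the scatter), concerns the ester and not the ring nitrogen, so no measured step bears directly on the change to compound 4, `CCOC(=O)c1ccc(-c2nn(-c3ccccc3)c3ccccc23)cc1`: phenyl in place of 4-methoxybenzyl on an aromatic nitrogen. Among the measured compounds shown here, with no comparable step on this position, the expectation is a modest weakening with wide uncertainty, a 2.4-fold higher number from compound 1 to compound 4 (0.38 log units; beyond the scatter). Compound 4 is estimated at 1500 nM, between 300 nM and 8000 nM.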

Compound 4, half-maximal inhibitory concentration: 2640 nM
Compound 4: middle estimate off by 1.8-fold (0.25 log units), on the low side, and the stated range covers the measured number.
By their numbers in this assay, from the lowest: compounds 2 and 1 (each within the scatter of the next); then compound 4. At a limit, above all of these: compound 3.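

In this assay the aromatic nitrogen proves sensitive to its substituent: phenyl in place of 4-methoxybenzyl brings a 4.3-fold higher number from compound 1 to compound 4 (0.63 log units; beyond the scatter) and still leaves a measured number, not a limit. Among these compounds, this is the first measured step at this position, and it is modest in size. Nothing shown here explains the step. The compounds leave open how a plain benzyl group would stand alongside the ethyl ester, which would separate the methoxy group from the rest of the change. As far as these compounds go, how an amine or a carboxylic acid on this nitrogen substituent would read also remains open.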